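The compounds below may be only part of what the source reports. "The series", "measured", "known", "first", "only" and "open" are said of these compounds alone.

Three compounds built on the same core differ only in the aryl group on an amine nitrogen in a ring. Compound 1 `Nc1scc(CN2CCN(c3ccc(Cl)cc3Cl)CC2)c1C(=O)c1ccc(Cl)cc1` gives -11% in a functional assay on CHO cells with adenosine receptor A1 (Homo sapiens) as the target, read by cAMP accumulation and immunoassay, with a stated time of 6 min, tested at 0.1 uM; on this read-out lower numbers stand for a stronger effect and higher numbers for a weaker effect at the one concentration tested. Compound 2 `Nc1scc(CN2CCN(c3cccc(Cl)c3Cl)CC2)c1C(=O)c1ccc(Cl)cc1` gives 3.2% in this assay, and compound 3 `Nc1scc(CN2CCN(c3cccc4ccccc34)CC2)c1C(=O)c1ccc(Cl)cc1` gives 0% in this assay. Compound 3 thus stands second highest of the three numbers: its nearest neighbour is compound 2, whose value lies within the scatter of its own, while compound 1 lies furthest away, the step of a number 11 percentage points higher from compound 1 to compound 3 (beyond the scatter) being beyond the scatter.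

Compound 4 `Nc1scc(CN2CCN(c3cc(F)ccc3F)CC2)c1C(=O)c1ccc(Cl)cc1` has not yet been measured. It differs from compound 3 in one place: 2,5-difluorophenyl in place of naphthalen-1-yl on an amine nitrogen in a ring. Going by the values given here, the steps that bear on this change are those in which the aryl group on the ring nitrogen was exchanged: a number 14.2 percentage points higher from compound 1 to compound 2 (beyond the scatter), a number 11 percentage points higher from compound 1 to compound 3 (beyond the scatter) and a number 3.2 percentage points lower from compound 2 to compound 3 (within the scatter). All three measured values sit close to zero, and no exchange of this aryl group has shifted the read-out by more than a modest amount. The expected step is therefore small, a number 2 percentage points lower from compound 3 to compound 4 (within the scatter), with no firm direction. Compound 4 is accordingly expected to give about -2% in this assay, within a range from -14% to 10%.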

Compound 4, a percentage reported as activity, at one concentration (the size of the read-out at that concentration, not a potency): -13%
The estimate for compound 4 lay 11 percentage points above the measured number; the range from low to high includes it.
By their numbers in this assay, from the lowest: compounds 4 and 1 (each within the scatter of the next); then compounds 3 and 2 (each within the scatter of the next).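

In this assay, the 2,5-difluorophenyl group brings the first clear step away from naphthalen-1-yl, a number 13 percentage points lower from compound 3 to compound 4 (beyond the scatter), and it also stands apart from 2,3-dichlorophenyl, with a number 16.2 percentage points lower from compound 2 to compound 4 (beyond the scatter). Against 2,4-dichlorophenyl, however, the exchange gives a number 2 percentage points lower from compound 1 to compound 4 (within the scatter), so a change of halogen and of substitution pattern together leaves the number where it was, and two halogens on the phenyl ring do not by themselves fix the read-out: compound 1 and compound 4 fall together, while compound 2 goes against any such grouping. The data shown offer no measurement that would account for this split.

Going by these compounds, it remains open whether a phenyl ring bearing a methoxy group, a nitrile or a single fluorine would read with compound 1 and compound 4 or with compound 2 and compound 3. On these data alone, with one concentration tested, it also remains open how these modest differences would translate into potency at this receptor.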